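The source may hold more compounds than are shown below. What is called first, only, known or untested is meant among the compounds shown, and "the series" means these compounds.

Measured compounds in an ADME assay on L929 cells (Mus musculus) for cytotoxicity; a lower number here means that less compound is tolerated, a higher number that more compound is tolerated:
compound 1 `CCCN(CCC)CCn1c2ccc3ccccc3c2c2nc3ccccc3nc21`: > 42600 nM.
compound 2 `CC1CCCCN1CCn1c2ccc3ccccc3c2c2nc3ccccc3nc21`: 113000 nM.

The value of compound 1 in this assay is a limit of the assay and not a number, so compound 1 stands only as a bound, without a fixed place among the numbers shown. In this assay compound 2 gives 113000 nM. The step that the limit leaves unreadable from compound 1 to compound 2 cannot be sized because compound 1 sits at the limit of > 42600 nM in this assay, at which 1 of the 2 values shown sits.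

Compound 3 `CC1CCN(CCn2c3ccc4ccccc4c3c3nc4ccccc4nc32)CC1` differs from compound 1 by 4-methylpiperidin-1-yl in place of dipropylamino on a saturated chain carbon, two bonds along the chain from an aromatic nitrogen. Going by the values given here, the one measured step that bears on this change, a ring amine in place of dipropylamino at the same place, is the one from compound 1 to compound 2, and its size is unreadable. No step beyond the scatter can therefore be expected in either direction, only a value of the same high order as both measured compounds.

Compound 3 is estimated at 90000 nM, between 30000 nM and 250000 nM, which is expected to mean a step that the limit leaves unreadable from compound 1 to compound 3.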

Compound 3, half-maximal cytotoxic concentration: > 214000 nM
Compound 3: only a limit was reported (the forecaster's own chance of this, stated with the estimate: 40%); at least 2.3-fold (0.37 log units) between middle value and limit.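

In this assay compound 3 gives > 214000 nM, which is a limit of the assay and not a number. Moving the methyl, with 4-methylpiperidin-1-yl in place of 2-methylpiperidin-1-yl at this place on the chain, gives an at least 1.8-fold higher number from compound 2 to compound 3 (0.27 log units; that floor lies within the scatter), so the position of the methyl on the ring has so far shown no change that clears the scatter, although the real difference could be larger than this floor. The step from compound 1 to compound 3 cannot be read, because compound 3 sits at a limit, as compound 1 also does: the limit of > 214000 nM in this assay, at which 1 of the 3 values shown sits.

Still open, on these data alone, is how far the tolerated amount of compound 3 extends beyond its limit. Also open, as far as these compounds go, is whether a morpholin-4-yl group, with an oxygen in the ring, or a longer chain to the core would leave this read-out as high.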